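The source may report more compounds than this note shows. Statements on the series, on what has been measured and on what is new or still open speak of the compounds shown alone.

Compound 1 `COc1cc(-c2nnc(SCC(=O)c3ccccc3)n2N)cc(OC)c1OC`: 7800 nM
Compound 2 `COc1cc(-c2nnc(SCC(=O)c3ccc(Br)cc3)n2N)cc(OC)c1OC`: 92500 nM
Compound 3 `COc1cc(-c2nnc(SCC(=O)c3ccc(C(F)(F)F)cc3)n2N)cc(OC)c1OC`: a limit of the assay, > 100000 nM

The series was read in a functional assay on HepG2 cells (Homo sapiens) for antiproliferative activity, read by MTT assay, with a stated time of 48 h; on this read-out lower numbers stand for stronger inhibition and higher numbers for weaker inhibition. Among the two numbers shown, compound 1 stands lowest; its nearest neighbour is compound 2, with a 12-fold higher number from compound 1 to compound 2 (1.07 log units; beyond the scatter). Compound 3 sits at the limit of > 100000 nM in this assay, at which 1 of the 3 values shown sits, giving an at least 12-fold higher number from compound 1 to compound 3 (1.10 log units; beyond the scatter). Between compound 2 and compound 3 the values show an at least 1.0-fold higher number from compound 2 to compound 3 (0.03 log units; that floor lies within the scatter).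

Compound 4 `COc1ccc(C(=O)CSc2nnc(-c3cc(OC)c(OC)c(OC)c3)n2N)cc1` has not yet been measured in this assay. It differs from compound 1 by methoxy in place of hydrogen on an aromatic carbon. The two measured steps that bear on it, from compound 1 to compound 2 and from compound 1 to compound 3, both place a group at the same position and both raised the number by a large amount. Methoxy is a different group from bromo or trifluoromethyl, and no methoxy analogue has been measured here, so the size is uncertain. Compound 4 is nonetheless expected to give a higher number than compound 1, estimated as a 3.2-fold higher number from compound 1 to compound 4 (0.51 log units; beyond the scatter). Compound 4 is expected at 25000 nM, within 7000 nM to 90000 nM.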

Compound 4, half-maximal inhibitory concentration: > 100000 nM
Compound 4: a limit, no number; the forecaster's own chance of this, stated with the estimate: 15%; middle value at least 4.0-fold (0.60 log units) from the limit.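

With methoxy on this aromatic carbon, para to a large group, this assay gives an at least 12-fold higher number from compound 1 to compound 4 (1.10 log units; beyond the scatter), so the loss seen with bromo and trifluoromethyl also appears with a third, different group. The comparison with the bromo compound gives only a floor, an at least 1.0-fold higher number from compound 2 to compound 4 (0.03 log units; that floor lies within the scatter), and the step between the two limits cannot be read. Compound 3 and compound 4 both stand at a limit, not at a number: the limit of > 100000 nM in this assay, at which 2 of the 4 values shown sit.

Hydrogen remains the only group shown at this place that gives a value as low as that of compound 1, and whether fluoro, hydroxyl or an amine would keep that value stays open. Going by these compounds, it is also open whether methoxy on another carbon of the same ring would give the same loss.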